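Swapping the Five-Membered Ring at the Para Position

A few compounds are considered here, and "the series" means these few. Any claim that something is new, unique, unknown or untested is made for them only; others in the source may bear on it.

The series shares one core, shown by compound 1 `COc1ccccc1C1C(C(=O)C(C)(C)C)=C(O)C(=O)N1c1ccc(-c2ccon2)cc1`, which in an ADME assay on the whole organism (Rattus norvegicus) for pharmacokinetics (on this read-out lower numbers stand for slow clearance and higher numbers for fast clearance), gives 1.3 mL/min/kg. Compound 2 `Cc1nc(-c2ccc(N3C(=O)C(O)=C(C(=O)C(C)(C)C)C3c3ccccc3OCCO)cc2)no1` carries a longer ether chain, and in this assay compound 2 stands at "not determined" (no result reported), so no number anchors it. Compound 3 `CC(C)(C)C(=O)C1=C(O)C(=O)N(c2ccc(-c3cccs3)cc2)C1c1ccccc1OCCO` differs from compound 2 by thiophen-2-yl in place of 5-methyl-1,2,4-oxadiazol-3-yl on an aromatic carbon. Going by the values given here, with no measured step available, the author expects any shift from compound 2 to compound 3 in this assay to stay within the usual scatter. Compound 3 is therefore estimated at 3 mL/min/kg, likely between 1 mL/min/kg and 12 mL/min/kg.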

Compound 3, clearance in the Rattus norvegicus assay: 1.3 mL/min/kg
For compound 3 the middle estimate is 2.3-fold (0.36 log units) above the measured one; the measured number falls inside the stated range.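

Going by these compounds alone, compound 2 stands at "not determined" (no result reported) in the Rattus norvegicus assay, so no step from compound 2 to compound 3 can be read there. Nothing given bears on this result. The compounds shown leave open how thiophen-2-yl and 5-methyl-1,2,4-oxadiazol-3-yl compare for clearance. In a physicochemical assay for solubility, in phosphate buffer, at pH 6.8 (a higher number here means a more soluble compound, a lower number a less soluble compound), compound 2 gives > 50000 nM, which is a limit of the assay and not a number. In the physicochemical assay compound 3 gives 38600 nM.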